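Swapping a difluorophenyl for a methoxyphenyl on a xanthine

The source may hold more compounds than are shown below. What is called first, only, known or untested is meant among the compounds shown, and "the series" means these compounds.

Measured so far:
- compound 1 `CCCn1c(=O)c2nc(-c3cnn(Cc4cccc(C)c4)c3)[nH]c2n(CCC)c1=O`: 36 nM
- compound 2 `CCCn1c(=O)c2nc(-c3cnn(Cc4c(F)cccc4F)c3)[nH]c2n(CCC)c1=O`: 390 nM
- compound 3 `CCCn1c(=O)c2nc(-c3cnn(Cc4cccc(F)c4F)c3)[nH]c2n(CCC)c1=O`: 240 nM

All three share one core and differ only in the aryl group carried on a saturated chain carbon bound to an aromatic nitrogen. In an in vitro assay on HEK293 cells for displacement of a labelled ligand from adenosine receptor A2b (Homo sapiens) (a lower number here means a stronger inhibitor, a higher number a weaker inhibitor), compound 3 stands second highest of the three numbers; its nearest neighbour is compound 2, and the two lie within the scatter of each other a 1.6-fold lower number from compound 2 to compound 3 (0.21 log units; within the scatter), while compound 1 sits furthest away a 6.7-fold higher number from compound 1 to compound 3 (0.82 log units; beyond the scatter).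

Compound 4 `CCCn1c(=O)c2nc(-c3cnn(Cc4ccccc4OC)c3)[nH]c2n(CCC)c1=O` has not yet been measured. Its change from compound 3 is 2-methoxyphenyl in place of 2,3-difluorophenyl on a saturated chain carbon bound to an aromatic nitrogen.

Going by the values given here, two measured steps bear on this move, both from the 3-methylphenyl of compound 1 to a difluorophenyl: an 11-fold higher number from compound 1 to compound 2 (1.03 log units; beyond the scatter) and a 6.7-fold higher number from compound 1 to compound 3 (0.82 log units; beyond the scatter). Among the compounds with values here, both fluorinated groups gave clearly higher numbers than the methyl one, but there is no measured compound with a methoxyphenyl, so the effect of adding that one acceptor is not known from these data. The step from compound 3 to compound 4 is therefore expected to be small, on the order of a 1.6-fold lower number from compound 3 to compound 4 (0.20 log units; within the scatter), with wide uncertainty. Compound 4 is estimated at 150 nM in this assay, within a range of 45 nM to 500 nM.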

Compound 4, inhibition constant: 37 nM
For compound 4 the middle estimate is 4.1-fold (0.61 log units) above the measured one; measured number below the stated range.
By their numbers in this assay, from the lowest: compounds 1 and 4 (each within the scatter of the next); then compounds 3 and 2 (each within the scatter of the next).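

In this assay, the 2-methoxyphenyl group gives a number level with that of the 3-methylphenyl group, a 1.0-fold higher number from compound 1 to compound 4 (0.01 log units; within the scatter), so two differently substituted aryl groups on a saturated chain carbon bound to an aromatic nitrogen can both sit at the low end of this small set. Against the two difluorophenyl compounds the change is clear, with a 6.5-fold lower number from compound 3 to compound 4 (0.81 log units; beyond the scatter) and an 11-fold lower number from compound 2 to compound 4 (1.02 log units; beyond the scatter), which shows that swapping one aryl group for another with the same count of 8 heavy atoms can still move the number well beyond the scatter. Nothing available here explains why the two difluorophenyl compounds give the higher numbers.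

As far as these compounds go, it remains open whether the low numbers need a substituent on the ring at all, which a plain phenyl would test, and whether an ethoxyphenyl with its longer chain or an aminophenyl would stay level with compound 1 and compound 4. From the compounds shown here alone, only one receptor appears in these data, so how this group of compounds behaves at other adenosine receptors also stays unknown.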